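The source may hold more compounds than are shown below. What is called first, only, known or untested is meant among the compounds shown, and "the series" means these compounds.

Measured in an ADME assay on HeLa cells (Homo sapiens) for cytotoxicity, read by MTT assay; a lower number here means a stronger inhibitor, a higher number a weaker inhibitor:
- Compound 1 `COc1ccc(C[C@H]2COC(=O)[C@@H]2Cc2ccc(OCC(=O)Nc3ccc(C)cc3)c(OC)c2)cc1OC`: 228000 nM
- Compound 2 `COC(=O)[C@@H](NC(=O)CCC(=O)Oc1ccc(C[C@H]2C(=O)OC[C@@H]2Cc2ccc(OC)c(OC)c2)cc1OC)C(C)C`: 64000 nM
- Compound 3 `COC(=O)[C@H](CC(C)C)NC(=O)CCC(=O)Oc1ccc(C[C@H]2C(=O)OC[C@@H]2Cc2ccc(OC)c(OC)c2)cc1OC`: 53200 nM

Compound 1 has the highest number of the three, clearly above the other two. Compound 4 `CCN(CC)C(=O)COc1ccc(C[C@H]2C(=O)OC[C@@H]2Cc2ccc(OC)c(OC)c2)cc1OC` has not yet been measured. It differs from compound 1 on a carbonyl carbon: diethylamino in place of (4-methylphenyl)amino on a carbonyl carbon. Within the data shown here, no measured step covers this change. The only one available, a 1.2-fold lower number from compound 2 to compound 3 (0.08 log units; within the scatter), lies elsewhere in the molecule and stays within the scatter, so it gives little guidance. Still, with a different chain on the shared core, compound 2 gives 64000 nM and compound 3 gives 53200 nM, so a number lower than that of compound 1 is possible. A small move in that direction is expected, a 1.9-fold lower number from compound 1 to compound 4 (0.28 log units; within the scatter). The estimate for compound 4 is 120000 nM, with an expected range from 45000 nM to 300000 nM.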

Compound 4, half-maximal inhibitory concentration: 188000 nM
Compound 4: middle estimate off by 1.6-fold (0.19 log units), on the low side; the range from low to high includes it.
By their numbers in this assay, from the lowest: compounds 3 and 2 (each within the scatter of the next); then compounds 4 and 1 (each within the scatter of the next).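

In this assay, among these compounds, diethylamino in place of (4-methylphenyl)amino on the carbonyl carbon gives a 1.2-fold lower number from compound 1 to compound 4 (0.08 log units; within the scatter) and is the first step read at this position. Here the aromatic ring and the amide hydrogen both leave, yet the number stays within the scatter. No measurement shown explains this result.

Still open, from the compounds shown here alone, is what dimethylamino, piperidin-1-yl or a free carboxylic acid would give on this carbonyl carbon. Also open, going by these compounds, is whether any group here can move the number beyond the scatter.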